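Methoxy in Place of Methyl Beside a Limit Value

This account rests on a few compounds, and the source may have more. Where it says the series, first, only, none or still open, it means among the compounds named here.

Compound 1, `CCOC(=O)C1=Cc2ccccc2OC1(OCc1cn(CC(=O)Nc2ccc(C)cc2)nn1)C(F)(F)F`: > 150000 nM in a functional assay on MCF7 cells (Homo sapiens) for inhibition, read by MTT assay, with a stated time of 24 h; a lower number here means a stronger inhibitor, a higher number a weaker inhibitor
Compound 2, `CCOC(=O)C1=Cc2ccccc2OC1(OCc1cc(-c2cccc(C(F)(F)F)c2)no1)C(F)(F)F`: 22100 nM in this assay

The value of compound 1 is a limit of this assay and not a number (the limit of > 150000 nM in this assay, at which 1 of the 2 values shown sits). Compound 2 gives a measured number. Compound 3, `CCOC(=O)C1=Cc2ccccc2OC1(OCc1cn(CC(=O)Nc2ccc(OC)cc2)nn1)C(F)(F)F`, differs from compound 1 by methoxy in place of methyl on an aromatic carbon. No measured step between two of these compounds exists, so the step that the limit leaves unreadable from compound 1 to compound 3 is expected to be none beyond the usual scatter of this assay. Compound 3 is therefore estimated at 200000 nM, with a range from 60000 nM to 600000 nM.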

Compound 3, half-maximal inhibitory concentration: 28100 nM
Estimate against measurement, compound 3: 7.1-fold (0.85 log units) above; measured number below the stated range.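

Methoxy in place of methyl on this aromatic carbon, para to a large group, is enough to bring the series into the measurable range of this assay: the change from 4-methylphenyl to 4-methoxyphenyl gives an at least 5.3-fold lower number from compound 1 to compound 3 (0.72 log units; beyond the scatter). Going by these compounds alone, the single added oxygen therefore changes the read-out at this position, which the earlier compounds could not show. The step has only a lower bound, and its full size stays unknown: the limit of > 150000 nM in this assay, at which 1 of the 3 values shown sits.

Going by these compounds, whether a hydroxyl, an amine or a chlorine at the same position would give a lower number than methoxy remains open. So does the effect of a longer alkoxy chain there.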